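A few compounds are considered here, and "the series" means these few. Any claim that something is new, unique, unknown or untested is made for them only; others in the source may bear on it.

In an ADME assay on BJ cells (Homo sapiens) for cytotoxicity, with a stated time of 72 h (on this read-out higher numbers stand for an effect only at larger amounts of compound and lower numbers for an effect already at smaller amounts), compound 1 `Cc1cc(NC(=O)Nc2ccc(C(C)(C)C)cc2)c2ccccc2n1` gives 20000 nM. Compound 3 `Cc1cc(NC(=O)Nc2ccccc2C(C)(C)C)c2ccccc2n1` gives 22000 nM, and these two values lie within the scatter of each other, so they cannot be ranked. For compound 2 `Cc1cc(NC(=O)Nc2ccccc2N)c2ccccc2n1`, the result is only a limit, > 25000 nM.

The next compound to consider is compound 4 `Cc1cc(NC(=O)Nc2ccc(N(C)C)cc2)c2ccccc2n1`. It carries dimethylamino in place of tert-butyl on an aromatic carbon, para to a large group, and the counted difference is dimethylamino in place of tert-butyl on an aromatic carbon.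

Among the compounds with values here, one measured step bears on this change, since it also exchanges tert-butyl and a group named with amino: an at least 1.1-fold lower number from compound 2 to compound 3 (0.05 log units; that floor lies within the scatter). That step involves a different pair of compounds and runs from amino to tert-butyl, so it is only a loose guide. Its floor does not show a change beyond the scatter. The data also include (the limit of > 25000 nM in this assay, at which 1 of the 3 values shown sits), so compound 4 may likewise return only a limit.

Going by compound 3 and its step of an at least 1.1-fold lower number from compound 2 to compound 3 (0.05 log units; that floor lies within the scatter), no shift beyond the scatter is expected in this assay, and any small drift would be toward a higher number. The expected change is a 1.1-fold higher number from compound 1 to compound 4 (0.04 log units; within the scatter). For compound 4, the estimated value is 22000 nM, with an expected range from 10000 nM to 40000 nM.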

Compound 4, half-maximal effective concentration: > 25000 nM
Compound 4: a limit, no number (the forecaster's own chance of this, stated with the estimate: 50%); at least 1.1-fold (0.05 log units) between middle value and limit.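

In this assay, putting dimethylamino in place of tert-butyl on this aromatic carbon, para to a large group, gives an at least 1.2-fold higher number from compound 1 to compound 4 (0.09 log units; that floor lies within the scatter). Within the data shown here, until now this position had been seen carrying only tert-butyl, so this is the first direct comparison of two groups there, and it swaps an all-carbon group for one that contains a nitrogen and counts one hydrogen-bond acceptor. The result for compound 4 is a limit and not a number, so the true size of the step cannot be read, and the printed floor alone does not separate the two compounds beyond the usual scatter; such limits now make up a large share of this small set: the limit of > 25000 nM in this assay, at which 2 of the 4 values shown sit.

The compounds shown leave open whether any group at this position can move the result beyond the scatter, in either direction. A carboxylic acid or a longer chain on this same carbon would extend the comparison, though only a result that comes back as a number, not a limit, could show how large such a change is.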